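Chloro to Fluoro on the Benzoyl Ring of Compound 1

The compounds below may be only part of what the source reports. "The series", "measured", "known", "first", "only" and "open" are said of these compounds alone.

Compound 1 `O=C(c1ccc(Cl)cc1)N1CC(c2nc(-c3cccc(F)c3)no2)C1` carries a 4-chlorophenyl on the carbonyl carbon of the shared core. In an assay on HEK293 cells for positive allosteric modulation of metabotropic glutamate receptor 5 (Homo sapiens), read by FLIPR (a higher number here means that more compound is needed for the effect, a lower number that less compound is needed), compound 1 gives 2500 nM, the highest of the two numbers recorded. Compound 3 `O=C(N1CCCCCC1)N1CC(c2nc(-c3cccc(Cl)c3)no2)C1`, with an azepan-1-yl on the carbonyl carbon, gives 47 nM in this assay, a far lower number. Compound 2 `O=C(C1CCCO1)N1CC(c2nc(-c3cccc(Cl)c3)no2)C1`, which bears an oxolan-2-yl on the carbonyl carbon, gives in this assay a value that is a limit of the assay, > 10000 nM. This is the limit of > 10000 nM in this assay, at which 1 of the 3 values shown sits. Within the data shown here, the one step measured between two neighbours, an at least 210-fold lower number from compound 2 to compound 3 (2.32 log units; beyond the scatter), concerns the group on the carbonyl carbon and does not touch the aromatic ring that changes here.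

Compound 4 `O=C(c1ccc(F)cc1)N1CC(c2nc(-c3cccc(F)c3)no2)C1` differs from compound 1 by the change (fluoro in place of chloro on an aromatic carbon). Among the measured compounds shown here, no measured step covers an exchange of halogen on this ring. From the change alone no step beyond the scatter in this assay is expected, and the number for compound 4 is expected to stay close to that of compound 1. The estimate for compound 4 is 3000 nM, within 1200 nM to 8000 nM. The expected step is a 1.2-fold higher number from compound 1 to compound 4 (0.08 log units; within the scatter).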

Compound 4, half-maximal effective concentration: 2400 nM
Beside the measured number, compound 4's estimate is 1.3-fold (0.10 log units) above it; low and high end bracket the measured number.
By their numbers in this assay, from the lowest: compound 3; then compounds 4 and 1 (each within the scatter of the next). At a limit, above all of these: compound 2.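

The exchange of 4-chlorophenyl for 4-fluorophenyl on the carbonyl carbon gives, in this assay, a 1.0-fold lower number from compound 1 to compound 4 (0.02 log units; within the scatter), so the two compounds cannot be told apart by this read-out. Among these compounds, this is the first measured exchange on this aromatic ring, and it shows that, on an aromatic carbon para to a large group, one halogen can stand in for the other here without a step beyond the scatter, whereas the only earlier step, which concerned the whole group on the carbonyl carbon, was large. Nothing measured among the compounds shown speaks to why chloro and fluoro give the same result at this place.

Going by these compounds, what remains open is whether this place tolerates only halogens or whether a group of another kind, such as a methoxy, a nitrile or an amine, or plain hydrogen in place of the halogen, would give a step beyond the scatter. Also open, on these data alone, is whether the same exchange would stay within the scatter at another place on this ring, or with a different group on the other side of the shared core.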